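This account rests on a few compounds, and the source may have more. Where it says the series, first, only, none or still open, it means among the compounds named here.

Measured compounds:
- compound 1, `O=C(CN1CCN(c2ccccn2)CC1)Nc1cccnc1`: in a functional assay on cells for antagonist activity at D(4) dopamine receptor (Homo sapiens), read by TR-FRET and cAMP accumulation, with a stated time of 30 min (on this read-out higher numbers stand for weaker inhibition and lower numbers for stronger inhibition), compound 1 gives 86500 nM
- compound 2, `Cc1cccc(NC(=O)CN2CCN(c3ccc(Cl)cn3)CC2)c1`: in this assay compound 2 gives 4700 nM

Of the two measured compounds, compound 2 stands at the lower number, and compound 1 is well apart from it, beyond the usual scatter. The two differ in more than one place, so the numbers alone do not show which part of the difference matters.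

The next compound, compound 3, `Cc1cccc(NC(=O)CN2CCN(c3ccccn3)CC2)c1`, is not yet measured. Compared with compound 2 it carries hydrogen in place of chloro on an aromatic carbon. In this respect compound 3 resembles compound 1, which also has no chloro on that ring, while it keeps the methyl-bearing aniline of compound 2.

Because compound 1 gives 86500 nM and compound 2 gives 4700 nM, and compound 3 sits between them in structure, the expected step of a 4.3-fold higher number from compound 2 to compound 3 (0.63 log units; beyond the scatter) is toward a higher number, and likely beyond the scatter, though its size is uncertain. Compound 3 is estimated to give 20000 nM, with an expected range from 5000 nM to 80000 nM.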

Compound 3, half-maximal inhibitory concentration: 82.7 nM
Beside the measured number, compound 3's estimate is 240-fold (2.38 log units) above it; the whole stated range lies above it.
By their numbers in this assay, from the lowest: compound 3; then compound 2; then compound 1.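

In this assay, going from 5-chloropyridin-2-yl to pyridin-2-yl gives a 57-fold lower number from compound 2 to compound 3 (1.75 log units; beyond the scatter), so the ring carbon two atoms from the ring nitrogen is a highly sensitive position, and in this pair the chloro there goes with much weaker inhibition. Compound 3 also isolates the change at the other end of the molecule: 3-methylphenyl in place of pyridin-3-yl on the amide-type nitrogen gives a 1000-fold lower number from compound 1 to compound 3 (3.02 log units; beyond the scatter), showing that the two changes pull in opposite directions, which the comparison of compound 1 with compound 2 could not reveal. Nothing available here explains the size or direction of either step.

The compounds shown leave open whether the large difference is specific to chloro, or whether a fluoro, methyl or methoxy group on the same ring carbon would also give a much higher number. They also do not tell whether the methyl of the 3-methylphenyl group contributes, a question that a plain phenyl group on the amide-type nitrogen would address.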